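The compounds below may be only part of what the source reports. "The series", "measured", "known", "first", "only" and "open" are said of these compounds alone.

In an ADME assay on the whole organism (Mus musculus, strain CD-1) for pharmacokinetics, at a dose of 10 mg/kg by the oral route (a higher number here means more compound in the circulation at the dose given, a lower number less compound in the circulation), compound 1 `COc1cc([C@](O)(CCN(C)C)[C@@H](c2cc3cc(Br)ccc3nc2OC)c2ccnc(OC)c2OC)cc(OC(C)C)n1` gives 5600 ng.h/mL and compound 2 `COc1cc([C@](O)(CCN(C)C)[C@@H](c2cc3cc(Br)ccc3nc2OC)c2ccnc(OC)c2OC)cc(OC(F)F)n1` gives 9800 ng.h/mL. Compound 3 `COc1cccc([C@H](c2cc3cc(Br)ccc3nc2OC)[C@@](O)(CCN(C)C)c2cc(SC)nc(SC)c2)c1F` gives 8400 ng.h/mL, which lies within the scatter of both. Compound 4 `COc1nc2ccc(Br)cc2cc1[C@@H](c1ccnc(OC)c1OC)[C@@](O)(CCN(C)C)c1cc(SC)nc(SC)c1` differs from compound 3 in a single exchange: 2,3-dimethoxypyridin-4-yl in place of 2-fluoro-3-methoxyphenyl on a saturated chain carbon bound to an aromatic carbon and a saturated chain carbon.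

Among the measured compounds shown here, no measured step covers this exchange directly. Compound 1 and compound 2 already carry the 2,3-dimethoxypyridin-4-yl group, but they differ from compound 4 elsewhere in the structure. For the measured compounds named here, the only measured step, a 1.8-fold higher number from compound 1 to compound 2 (0.24 log units; within the scatter), concerns another part of the molecule and stays within the scatter. Neither compound 1 nor compound 2 stands apart from compound 3 beyond the scatter, so the exchange is not expected to produce a step larger than the scatter in this assay, and no direction can be argued with any confidence. The expected step is small, a 1.1-fold lower number from compound 3 to compound 4 (0.05 log units; within the scatter). Compound 4 is estimated at 7500 ng.h/mL, with an expected range from 3500 ng.h/mL to 15000 ng.h/mL.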

Compound 4, area under the concentration-time curve: 3900 ng.h/mL
For compound 4 the middle estimate is 1.9-fold (0.28 log units) above the measured one; low and high end bracket the measured number.
By their numbers in this assay, from the lowest: compounds 4, 1, 3 and 2 (each within the scatter of the next, the first and the last beyond it).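

In this assay the exchange of 2-fluoro-3-methoxyphenyl for 2,3-dimethoxypyridin-4-yl gives a 2.2-fold lower number from compound 3 to compound 4 (0.33 log units; beyond the scatter) and so shows that this position can move the read-out by a modest step. With 2,3-dimethoxypyridin-4-yl held in place, the change on the saturated chain carbon bound to an oxygen gives a 2.5-fold lower number from compound 2 to compound 4 (0.40 log units; beyond the scatter) when it removes the difluoromethyl-bearing group, but a 1.4-fold lower number from compound 1 to compound 4 (0.16 log units; within the scatter) when it removes the isopropyl-bearing group, so the outcome depends on which group leaves. No measurement at hand gives a reason for any of these steps.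

On these data alone, the exchange at this position rests on a single pair, so its size with other partner groups stays open. A pyridin-4-yl group carrying a single methoxy could show whether the ring nitrogen or the second methoxy goes with the step.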